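The source may report more compounds than this note shows. Statements on the series, on what has been measured and on what is new or still open speak of the compounds shown alone.

Working notes on the series. In a functional assay on A549 cells (Homo sapiens) for inhibition, read by MTT assay, with a stated time of 24 h (on this read-out lower numbers stand for stronger inhibition and higher numbers for weaker inhibition), compound 1 (`CC1(C)[C@H]2CC[C@]1(C)N(Cc1cn(-c3ccc(C#N)cc3)nn1)C(=O)C2`) gives 140 nM, compound 2 (`CC1(C)[C@H]2CC[C@]1(C)N(Cc1cn(-c3ccccc3Cl)nn1)C(=O)C2`) gives 70 nM and compound 3 (`CC1(C)[C@H]2CC[C@]1(C)N(Cc1cn(-c3cccc(Cl)c3)nn1)C(=O)C2`) gives 60 nM. Compound 3 has the lowest of the three numbers, but it lies within the scatter of compound 2 and apart only from compound 1. The next structure is compound 4 (`CC1(C)[C@H]2CC[C@]1(C)N(Cc1cn(-c3ccccc3)nn1)C(=O)C2`), with the change hydrogen in place of chloro on an aromatic carbon. Going by the values given here, no measured step removes a chloro group, so this change has no direct test in the data. The expectation rests on two indirect steps. One is a 1.2-fold lower number from compound 2 to compound 3 (0.07 log units; within the scatter), which shows that the chloro position leaves the number within the scatter. Among the compounds with values here, the other is a 2.3-fold lower number from compound 1 to compound 3 (0.37 log units; beyond the scatter), the only step beyond the scatter, and it is modest. In this assay little or no step beyond the scatter is therefore expected, with any drift going towards a higher number. The estimated step is a 1.5-fold higher number from compound 3 to compound 4 (0.18 log units; within the scatter). For compound 4 the expected value is 90 nM, with an estimated range of 40 nM to 200 nM.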

Compound 4, half-maximal inhibitory concentration: 70 nM
Beside the measured number, compound 4's estimate is 1.3-fold (0.11 log units) above it; the measured number falls inside the stated range.
By their numbers in this assay, from the lowest: compounds 3, 2, 4 and 1 (each within the scatter of the next, the first and the last beyond it).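

In this assay the loss of the chloro group now has a direct test: a 1.2-fold higher number from compound 3 to compound 4 (0.07 log units; within the scatter) and no change at the digits printed from compound 2 to compound 4 (within the scatter), so the plain phenyl is not separated from either chloro compound and a chloro group is not required for a number in this range. The cyano group gives the same picture, with a 2.0-fold lower number from compound 1 to compound 4 (0.30 log units; within the scatter), which leaves the step from compound 1 to compound 3 as the only one beyond the scatter, and compound 4 within the scatter of both. The data hold no evidence that bears on this result.

The compounds shown leave open whether an amine, a carboxylic acid or a methoxy group on the phenyl would carry the number beyond the scatter of compound 4. They also leave open what a longer chain in place of the phenyl would do.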